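A few compounds are considered here, and "the series" means these few. Any claim that something is new, unique, unknown or untested is made for them only; others in the source may bear on it.

Working notes on the series. Compound 1 `O=C1COc2ccc(-c3[nH]c(-c4ccc(C(F)(F)F)cc4)nc3-c3ccccc3)cc2N1` carries the shared core with a 4-(trifluoromethyl)phenyl group. Among the compounds with values here, in a functional assay on A549 cells (Homo sapiens) for cytotoxicity, read by colorimetric assay and MTT assay, with a stated time of 3 days, tested at 1 uM (a higher number here means a weaker effect of the compound at the concentration tested, a lower number a stronger effect), compound 1 gives 103%, the higher of the two numbers measured so far, so at this concentration compound 1 shows essentially no effect. The second measured compound, compound 2 `O=C1COc2ccc(-c3nn(-c4ccccc4)cc3-c3ccccc3)cc2N1`, has a different arrangement within the five-membered ring; in this assay compound 2 gives 92.2%, a number lower than that of compound 1 by more than the scatter. Within the data shown here, no single-place step between measured compounds is available, so the two values are read only as they stand.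

The next compound, compound 3 `O=C1COc2ccc(-c3[nH]c(-c4ccc(Cl)cc4Cl)nc3-c3ccccc3)cc2N1`, differs from compound 1 in one place: 2,4-dichlorophenyl in place of 4-(trifluoromethyl)phenyl on an aromatic carbon. Both groups have no hydrogen-bond donors or acceptors and no net charge. Given that compound 1 sits at 103%, compound 3 is expected to stay near it, with a step of a number 5 percentage points lower from compound 1 to compound 3 (within the scatter) that does not go beyond the scatter in either direction. Compound 3 is therefore estimated at 98%, within a range from 85% to 110%.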

Compound 3, a percentage reported as activity, at one concentration (the size of the read-out at that concentration, not a potency): 97.4%
For compound 3 the middle estimate is 0.6 percentage points above the measured one; the range from low to high includes it.
By their numbers in this assay, from the lowest: compounds 2, 3 and 1 (each within the scatter of the next, the first and the last beyond it).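

Within the data shown here, the swap on this aromatic carbon of the five-membered aromatic ring, between two ring nitrogen atoms, gives the first single-place comparison: in this assay it amounts to a number 5.6 percentage points lower from compound 1 to compound 3 (within the scatter), so 2,4-dichlorophenyl and 4-(trifluoromethyl)phenyl cannot be told apart here. The position therefore tolerates this exchange of one halogen-bearing phenyl group for another without a change beyond the scatter, and compound 3, at 97.4%, like compound 1 shows essentially no effect at the concentration tested. No measurement at hand bears on why the two groups read alike.

As far as these compounds go, both groups leave the position with one six-membered aromatic ring of carbon only and no hydrogen-bond donors or acceptors, so it remains open whether an amine, a carboxylic acid or a longer chain on this aromatic carbon would bring the number down. From the compounds shown here alone, with a single concentration behind each value, it also remains open whether compound 1 and compound 3 would still read alike at other concentrations.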